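Notes on two methoxy positions in the series

This account rests on a few compounds, and the source may have more. Where it says the series, first, only, none or still open, it means among the compounds named here.

Measured so far:
compound 1 `COc1ccc(-c2[nH]c3ccccc3c2/C=C(\C#N)S(=O)(=O)c2ccccc2)cc1` — > 100000 nM (a limit)
compound 2 `COc1ccc(-c2[nH]c3ccc(OC)cc3c2/C=C(\C#N)S(=O)(=O)c2ccccc2)cc1` — 40000 nM

In a functional assay on MCF7 cells (Homo sapiens) for cytotoxicity, read by MTT assay, with a stated time of 96 h (on this read-out higher numbers stand for an effect only at larger amounts of compound and lower numbers for an effect already at smaller amounts), compound 1 reaches only a limit, > 100000 nM. Among the measured compounds shown here, compound 2 gives 40000 nM, the only number in this assay. The other result shown, that of compound 1, is a limit (the limit of > 100000 nM in this assay, at which 1 of the 2 values shown sits). The step of an at least 2.5-fold lower number from compound 1 to compound 2 (0.39 log units; beyond the scatter) concerns the methoxy on the shared core. Compound 3 `COc1ccc2[nH]c(-c3ccccc3)c(/C=C(\C#N)S(=O)(=O)c3ccccc3)c2c1` differs from compound 2 by hydrogen in place of methoxy on an aromatic carbon, para to a large group. For the measured compounds named here, no measured step touches this methoxy, so the step from compound 1 to compound 2 is no direct guide. A change within the scatter is expected, a 1.3-fold higher number from compound 2 to compound 3 (0.10 log units; within the scatter), direction open. Compound 3 is estimated at 50000 nM, range 15000 nM to 150000 nM.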

Compound 3, half-maximal effective concentration: 12000 nM
Compound 3: middle estimate off by 4.2-fold (0.62 log units), on the high side, outside the stated range (below it).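

Going from 4-methoxyphenyl to phenyl gives a 3.3-fold lower number from compound 2 to compound 3 (0.52 log units; beyond the scatter) in this assay, so this position does respond to the change, and losing the methoxy here goes with a lower number. The two methoxy positions therefore do not act alike: on the shared core, methoxy in place of hydrogen goes with a lower number, whereas here hydrogen in place of methoxy does. No measurement shown bears on the cause of this step. Still open, from the compounds shown here alone, is whether a hydroxyl or an amine at this place would lower the number further. Also open, going by these compounds, is the result with hydrogen at both positions.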